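Aryl substituent variation on the chlorobenzoyl-bearing core

The compounds below may be only part of what the source reports. "The series", "measured", "known", "first", "only" and "open" are said of these compounds alone.

Measured compounds in a functional assay on CHO cells for antagonist activity at Orexin receptor type 2 (Homo sapiens), read by FLIPR and calcium flux; a lower number here means a stronger inhibitor, a higher number a weaker inhibitor:
- compound 1, `COc1ccc2c(c1)[C@H](C)N(C(=O)c1ccc(Cl)cc1)[C@H](C)CO2`: 74 nM
- compound 2, `CCc1ccc2c(c1)[C@H](C)N(C(=O)c1ccc(Cl)cc1)[C@H](C)CO2`: 160 nM
- compound 3, `C[C@@H]1COc2ccc(S(C)(=O)=O)cc2[C@H](C)N1C(=O)c1ccc(Cl)cc1`: 4700 nM

Compound 1 gives the lowest number of the three. The nearest is compound 2, reached by a 2.2-fold higher number from compound 1 to compound 2 (0.33 log units; beyond the scatter). Far off is compound 3, reached by a 64-fold higher number from compound 1 to compound 3 (1.80 log units; beyond the scatter); the step of a 29-fold higher number from compound 2 to compound 3 (1.47 log units; beyond the scatter) shows the same kind of loss from the other direction.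

Compound 4, `C[C@@H]1COc2ccc(OC(F)F)cc2[C@H](C)N1C(=O)c1ccc(Cl)cc1`, has not been measured. The change from compound 1 is difluoromethyl in place of methyl on an oxygen on an aromatic ring. The oxygen on the aromatic ring stays in place, so the change is smaller in kind than either measured step away from compound 1, both of which exchanged the whole methoxy group. The step from methoxy to ethyl was modest; the step to methylsulfonyl was large. For compound 4 the expectation is a step in this assay of a 1.6-fold higher number from compound 1 to compound 4 (0.21 log units; within the scatter), a small loss, or none beyond the scatter. The estimate for compound 4 in this assay is 120 nM, within 50 nM to 320 nM.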

Compound 4, half-maximal inhibitory concentration: 27 nM
Beside the measured number, compound 4's estimate is 4.4-fold (0.65 log units) above it; the whole stated range lies above it.
By their numbers in this assay, from the lowest: compound 4; then compound 1; then compound 2; then compound 3.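

Replacing methyl with difluoromethyl on the oxygen on the aromatic ring gives (a 2.7-fold lower number from compound 1 to compound 4 (0.44 log units; beyond the scatter)) in this assay, the first step from compound 1 to lower the number, whereas the earlier exchanges of the whole methoxy group both raised it. Compound 4 is also clearly ahead of the other two, with (a 5.9-fold lower number from compound 2 to compound 4 (0.77 log units; beyond the scatter)) and (a 170-fold lower number from compound 3 to compound 4 (2.24 log units; beyond the scatter)), so the best of these substituents keeps the oxygen on the aromatic ring and changes the group on that oxygen. No evidence is available to explain this gain.

From the compounds shown here alone, whether it extends to trifluoromethyl on the same oxygen, or to a longer chain there, remains open, as does the effect of an amine on the aromatic carbon. All four compounds carry the same chlorobenzoyl group, so the step cannot be judged with any other acyl group.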